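Fluoro to hydroxy on the chain of compound 1

The compounds below may be only part of what the source reports. "The series", "measured", "known", "first", "only" and "open" are said of these compounds alone.

Compound 1 `Cc1cn([C@H]2C[C@H](CF)[C@@H](CO)O2)c(=O)[nH]c1=O` is the parent of this small set. In an assay on isolated protein for inhibition of thymidine kinase, cytosolic (Homo sapiens) (on this read-out higher numbers stand for weaker inhibition and lower numbers for stronger inhibition), compound 1 gives 970000 nM, the highest number among the three measured compounds. Compound 2 `Cc1cn([C@H]2C[C@H](CF)[C@@H](COP(=O)(O)O)O2)c(=O)[nH]c1=O` gives 40000 nM in this assay, and compound 3 `Cc1cn([C@H]2C[C@H](CN=[N+]=[N-])[C@@H](COP(=O)(O)O)O2)c(=O)[nH]c1=O` gives 32000 nM. Among the compounds with values here, the single step of a 24-fold lower number from compound 1 to compound 2 (1.38 log units; beyond the scatter) is large, whereas the step of a 1.3-fold lower number from compound 2 to compound 3 (0.10 log units; within the scatter) is small.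

Compound 4 `Cc1cn([C@H]2C[C@H](CO)[C@@H](CO)O2)c(=O)[nH]c1=O` is not yet measured. It differs from compound 1 by hydroxy in place of fluoro on a saturated chain carbon bound to a saturated ring carbon.

Within the data shown here, no measured step swaps fluoro for hydroxy. Among the measured compounds shown here, the one step that touches the same place, a 1.3-fold lower number from compound 2 to compound 3 (0.10 log units; within the scatter), exchanges fluoro for azido and stays within the scatter, which is the only guide to how this assay responds to changes at that position. The large step of a 24-fold lower number from compound 1 to compound 2 (1.38 log units; beyond the scatter) concerns a different place and does not bear on the present change. The number for compound 4 in this assay is therefore expected to stay close to that of compound 1, with no step beyond the scatter in either direction.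

The expected step is a 1.0-fold higher number from compound 1 to compound 4 (0.01 log units; within the scatter). For compound 4 the estimate in this assay is 1000000 nM, with a range from 300000 nM to 3000000 nM.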

Compound 4, inhibition constant: 420000 nM
Estimate against measurement, compound 4: 2.4-fold (0.38 log units) above, within the range that was stated.
By their numbers in this assay, from the lowest: compounds 3 and 2 (each within the scatter of the next); then compound 4; then compound 1.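

Hydroxy in place of fluoro on a saturated chain carbon bound to a saturated ring carbon gives a 2.3-fold lower number from compound 1 to compound 4 (0.36 log units; beyond the scatter) in this assay and so shows that this position can move the number beyond the scatter. Within the data shown here, the only earlier change at this place, a 1.3-fold lower number from compound 2 to compound 3 (0.10 log units; within the scatter) for azido in place of fluoro, had stayed within the scatter and on its own gave no sign of this. The new step is still only modest, whereas the change at the oxygen on a saturated carbon, a 24-fold lower number from compound 1 to compound 2 (1.38 log units; beyond the scatter) for the phosphate in place of hydrogen, remains large.

On these data alone, it remains open whether hydroxy in place of fluoro gives a step of similar size on a compound that carries the phosphate, as the hydroxy step here was read only on a compound without it. An amine or a carboxylic acid on the same chain carbon, or a longer chain in place of hydroxymethyl, would show whether the change in number continues beyond these few groups, and nothing available here bears on the cause of the step.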